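The compounds below may be only part of what the source reports. "The series", "measured", "known", "first", "only" and "open" are said of these compounds alone.

Measured so far in an assay for inhibition of beta-glucuronidase (Bos taurus), read by spectrophotometry, with a stated time of 30 min; on this read-out lower numbers stand for stronger inhibition and higher numbers for weaker inhibition:

- compound 1, `COC(=O)C1=C(C)NC(=O)NC1c1ccccc1`: in this assay compound 1 gives "not active" (no number reported), no number being reported
- compound 2, `CCC1NC(=O)NC(C)=C1C(=O)OC`: in this assay compound 2 gives 52200 nM
- compound 3, `CCCCC1NC(=O)NC(C)=C1C(=O)OC`: in this assay compound 3 gives 78200 nM

For the measured compounds named here, compound 3 holds one of only two numbers. Its nearest neighbour is compound 2, and the step of a 1.5-fold higher number from compound 2 to compound 3 (0.18 log units; within the scatter) leaves the two indistinguishable, so neither can be placed above or below the other; compound 1 adds no number to compare against.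

Compound 4, `COC(=O)C1=C(C)NC(=O)NC1CC(C)C`, differs from compound 3 by isopropyl in place of propyl on a saturated chain carbon bound to a saturated ring carbon; the two have the same atoms, joined differently, and the same difference, cut one bond further out, reads: butyl to isobutyl. Going by the values given here, the only measured step that bears on the chain at this position is a 1.5-fold higher number from compound 2 to compound 3 (0.18 log units; within the scatter), which lengthened the chain and stayed within the scatter. Among the compounds with values here, no measured step rearranges a chain without changing its size, so there is nothing that points to a shift in either direction.

Compound 4 is therefore expected to give about 78000 nM in this assay, between 35000 nM and 175000 nM, an estimated step of a 1.0-fold lower number from compound 3 to compound 4 (0.00 log units; within the scatter) from compound 3 that stays within the scatter.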

Compound 4, half-maximal inhibitory concentration: 55200 nM
The estimate for compound 4 lay 1.4-fold (0.15 log units) above the measured number; the range from low to high includes it.
By their numbers in this assay, from the lowest: compounds 2, 4 and 3 (each within the scatter of the next).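

In this assay, butyl to isobutyl on a saturated chain carbon bound to a saturated ring carbon gives a 1.4-fold lower number from compound 3 to compound 4 (0.15 log units; within the scatter); this tests the shape of the chain with its atoms unchanged, which the earlier pair of numbers could not do. Against the shorter chain of compound 2, the same branched chain gives a 1.1-fold higher number from compound 2 to compound 4 (0.02 log units; within the scatter), so neither chain length nor branching separates compounds 2, 3 and 4, and none of the three can be placed above another. No measured evidence on the series bears on this result, and it gives no ground for an explanation.

From the compounds shown here alone, whether an amine, a carboxylic acid or a longer chain such as octyl at this position would move the number beyond the scatter remains open. Also open is what lies behind the read-out of compound 1, which gives "not active" (no number reported), since that entry carries no number to set against the three chain compounds.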